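Acylation of a ring hydroxy in an inactive series

The source may report more compounds than this note shows. Statements on the series, on what has been measured and on what is new or still open speak of the compounds shown alone.

Compound 1 `C=C1C(=O)O[C@@H]2[C@@H]3[C@@]4(C=C[C@@]3(C)[C@]3(C4)C(=O)O[C@@H]4[C@H]5C(C)=CC[C@H]5[C@](C)(O)C[C@H](O)[C@H]43)[C@](C)(O)CC[C@@H]12` is the reference point of this set. In a functional assay on CNE cells (Homo sapiens) for cytotoxicity, read by MTT assay, with a stated time of 48 h (a higher number here means a weaker inhibitor, a lower number a stronger inhibitor), compound 1 gives > 10000 nM, which is a limit of the assay and not a number. Compound 2 `C/C=C(\C)C(=O)O[C@H]1C[C@@](C)(O)[C@]23C=C[C@](C)([C@@H]2[C@H]2OC(=O)[C@@H](C)[C@@H]21)[C@]1(C3)C(=O)O[C@@H]2[C@H]3C(C)=CC[C@H]3[C@](C)(O)C[C@H](O)[C@H]21` carries two ester groups on the shared core. In this assay compound 2 gives > 10000 nM, again a limit. Compound 3 `C=C1C(=O)O[C@H]2[C@H]1[C@@H](O)C[C@@](C)(O)[C@]13C=C[C@](C)([C@H]21)[C@]1(C3)C(=O)O[C@@H]2[C@H]3C(C)=CC[C@H]3[C@](C)(O)C[C@H](OC(=O)/C(C)=C\C)[C@H]21` carries a single ester of the same kind together with a further hydroxy. In this assay compound 3 gives > 10000 nM, also a limit. Compound 1 therefore stands exactly where the other two stand, with nothing to separate them, as shown by the limit of > 10000 nM in this assay, at which 3 of the 3 values shown sit. Going by the values given here, no step between measured compounds can be computed, since no pair gives two numbers.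

Compound 4 `C=C1C(=O)O[C@@H]2[C@@H]3[C@@]4(C=C[C@@]3(C)[C@]3(C4)C(=O)O[C@@H]4[C@H]5C(C)=CC[C@H]5[C@](C)(O)C[C@H](OC(=O)/C(C)=C/C)[C@H]43)[C@](C)(O)CC[C@@H]12` differs from compound 1 by (1-methylprop-1-en-1-yl)carbonyl in place of hydrogen on an oxygen on a saturated carbon. Compound 3 already carries an ester of this kind on a hydroxy of the core and in this assay remains at a limit. On that basis the expected step that the limit leaves unreadable from compound 1 to compound 4 is none beyond the scatter. Compound 4 is therefore estimated at 15000 nM, within a range of 5000 nM to 50000 nM, with a strong chance that the assay again returns only a limit.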

Compound 4, half-maximal inhibitory concentration: > 10000 nM
Compound 4 ended at the assay's limit (the forecaster's own chance of this, stated with the estimate: 80%); the middle value does not contradict the limit.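

Compound 1 and compound 4 both stay at the limit in this assay and so no step can be read for this acylation of the ring hydroxy: the limit of > 10000 nM in this assay, at which 4 of the 4 values shown sit.

The compounds shown leave open how large any effect of the (1-methylprop-1-en-1-yl)carbonyl group is, and whether any change on the shared core gives a readable number in this assay at all.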